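The compounds below may be only part of what the source reports. "The series", "measured", "known", "first", "only" and "open" are said of these compounds alone.

In a functional assay on HCT-116 cells (Homo sapiens) for inhibition, read by MTT assay, with a stated time of 48 h (on this read-out higher numbers stand for weaker inhibition and lower numbers for stronger inhibition), three compounds have been measured:

Compound 1 `COc1ccc(N(C)c2nc(C)nc3ccccc23)cc1C(=O)OCC[Se]C#N`: 951 nM
Compound 2 `COc1ccc(N(C)c2nc(C)nc3ccccc23)cc1C(=O)NCC[Se]C#N`: 313 nM
Compound 3 `Cc1nc(N(C)c2ccc([Se]C#N)c(Cl)c2)c2ccccc2n1`: 12 nM

Compound 2 holds the second highest of these three numbers, with compound 1 above it and compound 3 below it. Compound 4 `COc1ccc(N(C)c2nc(C)nc3ccccc23)cc1OCCCC[Se]C#N` differs from compound 2 on an aromatic carbon, ortho to a methoxy group (a group of 8 heavy atoms (5 carbon, 1 nitrogen, 1 oxygen, 1 selenium; no ring) in place of a group of 8 heavy atoms (4 carbon, 2 nitrogen, 1 oxygen, 1 selenium; no ring), on an aromatic carbon). Among the compounds with values here, one measured step bears on this change: a 3.0-fold lower number from compound 1 to compound 2 (0.48 log units; beyond the scatter), which altered the same chain but kept its carbonyl. Compound 4 has no such carbonyl, so this modest step is only a loose guide. A change of similar modest size is expected in this assay, with no direction favoured. The expected step is a 1.0-fold lower number from compound 2 to compound 4 (0.02 log units; within the scatter), so no clear shift is expected. Compound 4 is estimated at 300 nM, with an expected range of 90 nM to 1000 nM.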

Compound 4, half-maximal inhibitory concentration: 512 nM
Beside the measured number, compound 4's estimate is 1.7-fold (0.23 log units) below it; low and high end bracket the measured number.
By their numbers in this assay, from the lowest: compound 3; then compounds 2, 4 and 1 (each within the scatter of the next, the first and the last beyond it).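

In this assay this aromatic carbon, ortho to a methoxy group, takes a chain with no carbonyl and no hydrogen-bond donor without a clear shift: the record gives a 1.6-fold higher number from compound 2 to compound 4 (0.21 log units; within the scatter) against the amide and a 1.9-fold lower number from compound 1 to compound 4 (0.27 log units; within the scatter) against the ester. Neither the carbonyl nor the amide hydrogen is therefore needed for a reading of this order on this chain. Nothing measured here speaks to the cause of these readings. As far as these compounds go, whether a shorter chain, a longer chain or an amine linker at this place would shift the number stays open.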